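Cytotoxicity Limits for a Cyclopentyl and Two Benzyl Variants

A few compounds are considered here, and "the series" means these few. Any claim that something is new, unique, unknown or untested is made for them only; others in the source may bear on it.

Compound 1 `O=c1nc(N2CCN(NCC3CCCC3)CC2)sc2c([N+](=O)[O-])cc(C(F)(F)F)cc12` gives > 64 ug/mL in an ADME assay on Vero cells (Chlorocebus sabaeus) for cytotoxicity, read by MTT assay, with a stated time of 72 h; a lower number here means that less compound is tolerated, a higher number that more compound is tolerated.
Compound 2 `O=c1nc(N2CCN(NCc3ccc(OC(F)(F)F)cc3)CC2)sc2c([N+](=O)[O-])cc(C(F)(F)F)cc12` gives > 64 ug/mL in this assay.

The value of compound 1 is a limit of the assay rather than a number. The value of compound 2 is likewise a limit. Going by the values given here, the one measured step, a step that the two limits leave unreadable from compound 1 to compound 2, therefore cannot be read, and the only evidence is the limit of > 64 ug/mL in this assay, at which 2 of the 2 values shown sit.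

Compound 3 `O=c1nc(N2CCN(NCc3ccc(C(F)(F)F)cc3)CC2)sc2c([N+](=O)[O-])cc(C(F)(F)F)cc12` is not yet measured. It differs from compound 2 in one place: trifluoromethyl in place of trifluoromethoxy on an aromatic carbon. Among the compounds with values here, no measured step bears on this change, and the two values shown sit at the same limit, so there is no measured step whose size could guide the expectation in this assay.

On this basis the step that the limit leaves unreadable from compound 2 to compound 3 is expected to show no change beyond the scatter. The estimate for compound 3 in this assay is 90 ug/mL, with a range from 45 ug/mL to 180 ug/mL, and the assay is expected most likely to return only a limit.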

Compound 3, half-maximal cytotoxic concentration: > 64 ug/mL
Compound 3: no number, only a limit; the forecaster's own chance of this, stated with the estimate: 80%; the middle value is on the limit's open side.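

In this assay compound 3 gives > 64 ug/mL, which is a limit of the assay and not a number. Neither step to compound 3, from compound 1 or from compound 2, can be read. The compounds shown leave open what concentration of compound 1, compound 2 or compound 3 reaches the half-maximal effect in this assay, and whether the three differ at all.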